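A few compounds are considered here, and "the series" means these few. Any claim that something is new, unique, unknown or untested is made for them only; others in the source may bear on it.

Measured so far in a functional assay on MCF7 cells (Homo sapiens) for inhibition, read by MTT assay, with a stated time of 48 h; on this read-out lower numbers stand for stronger inhibition and higher numbers for weaker inhibition:

Compound 1 `Fc1ccc(CSc2nnc(-c3ccncc3)n2-c2ccccc2)cc1`: 21100 nM
Compound 2 `Clc1ccc(CSc2nnc(-c3ccncc3)n2-c2ccccc2)cc1`: 13300 nM
Compound 3 `O=C(CSc1nnc(-c2ccncc2)n1-c1ccccc1)N/N=C/c1ccc(Cl)cc1`: 9930 nM

Compound 1 and compound 2 share a core and differ only at one aromatic carbon: fluoro in place of chloro on an aromatic carbon. On this change the half-maximal inhibitory concentration moved by a 1.6-fold higher number from compound 2 to compound 1 (0.20 log units; within the scatter), so the swap left the read-out essentially unchanged between these two compounds.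

Compound 3 carries a different core; the difference between its core and that of compound 2 is not broken down here. Its value in this assay sits nearest to that of compound 2, the two within the scatter, while the gap to compound 1 lies just beyond it.

Compound 4 `O=C(CSc1nnc(-c2ccncc2)n1-c1ccccc1)N/N=C/c1ccc(F)cc1` is not yet measured. It differs from compound 3 by the same change seen from compound 2 to compound 1: fluoro in place of chloro on an aromatic carbon. Among the measured compounds shown here, the only guide is the step already recorded, a 1.6-fold higher number from compound 2 to compound 1 (0.20 log units; within the scatter), and a step of similar size, a 1.5-fold higher number from compound 3 to compound 4 (0.18 log units; within the scatter), is expected from compound 3 to compound 4. Compound 4 is therefore estimated at 15000 nM in this assay, with a range from 8000 nM to 30000 nM.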

Compound 4, half-maximal inhibitory concentration: 12300 nM
Estimate against measurement, compound 4: 1.2-fold (0.09 log units) above; the range from low to high includes it.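

In this assay, the change from 4-chlorophenyl to 4-fluorophenyl gives a 1.2-fold higher number from compound 3 to compound 4 (0.09 log units; within the scatter), and it matches the step on the other core: the same change on two cores in this assay, a 1.6-fold higher number (0.20 log units; within the scatter) from compound 2 to compound 1 and a 1.2-fold higher number (0.09 log units; within the scatter) from compound 3 to compound 4, 1.3-fold (0.11 log units) apart, within the scatter of two such steps

On these two cores, then, fluoro in place of chloro carries over as a step that cannot be told from the scatter, and neither core stands apart in its response. Among the compounds shown here, this does not show that the change is inert or transfers in general: there are only two pairs, both steps lie within the scatter, and agreement between two small steps says little about how a larger step would carry from one core to another.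

The compounds shown leave open whether an amine, a methoxy group or a carboxylic acid in place of the halogen on this aromatic carbon would move the read-out beyond the scatter on either core. They also leave open whether the agreement between the cores would hold for such a group, and whether it would hold outside this assay.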